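Benzoyl in place of benzyl on compound 3

The source may hold more compounds than are shown below. What is called first, only, known or untested is meant among the compounds shown, and "the series" means these compounds.

In a functional assay on NCI-H460 cells (Homo sapiens) for cytotoxicity (a lower number here means a stronger inhibitor, a higher number a weaker inhibitor), compound 3 `COc1ccc(S(=O)(=O)N2CCc3cccc(NCc4ccccc4)c32)cc1` gives > 10000 nM as its reading, which is a limit of the assay and not a number. Compound 4 `COc1ccc(S(=O)(=O)N2CCc3cccc(NC(=O)c4ccccc4)c32)cc1` differs from it by one change, benzoyl in place of benzyl on a nitrogen on an aromatic ring. The count of that change reads benzoyl in place of benzyl on a nitrogen on an aromatic ring and the same difference can be called benzylamino to benzamido.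

Compound 2 `COc1ccc(S(=O)(=O)N2CCc3cccc(NC(=O)c4ccc(F)cc4)c32)cc1` offers the closest comparison with 95 nM as its value. Replacing its (4-fluorophenyl)carbonyl with benzyl gives an at least 100-fold higher number from compound 2 to compound 3 (2.02 log units; beyond the scatter) as the step, the same kind of swap run the other way. Compound 1 `COc1ccc(S(=O)(=O)N2CCc3cccc(NC(=O)c4ccc([N+](=O)[O-])cc4)c32)cc1` gives 122 nM in this assay and the nitro and fluoro pair shows a 1.3-fold lower number from compound 1 to compound 2 (0.11 log units; within the scatter) as its step, so the group on that ring is not expected to matter much.

A large move toward a lower number is expected, an estimated at least 90-fold lower number from compound 3 to compound 4 (1.95 log units; beyond the scatter) in this assay overall. Compound 4 is estimated at 110 nM and is expected to fall between 40 nM and 350 nM.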

Compound 4, half-maximal inhibitory concentration: 257 nM
Estimate against measurement, compound 4: 2.3-fold (0.37 log units) below; low and high end bracket the measured number.
By their numbers in this assay, from the lowest: compounds 2 and 1 (each within the scatter of the next); then compound 4. At a limit, above all of these: compound 3.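

In this assay, the benzoyl for benzyl swap also holds on a ring carrying neither fluoro nor nitro, with an at least 38-fold lower number from compound 3 to compound 4 (1.59 log units; beyond the scatter). The substituent on that ring is not without effect, since hydrogen in place of fluoro gives a 2.7-fold higher number from compound 2 to compound 4 (0.43 log units; beyond the scatter) and hydrogen in place of nitro gives a 2.1-fold higher number from compound 1 to compound 4 (0.32 log units; beyond the scatter), both modest beside the step at the nitrogen, even though fluoro and nitro sit within the scatter of each other. The reading of compound 3 is a limit and not a number: the limit of > 10000 nM in this assay, at which 1 of the 4 values shown sits.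

The compounds shown leave open whether a urea or a sulfonamide at this nitrogen would keep the activity seen with benzoyl. They also leave open how an amine or a carboxylic acid on the benzoyl ring would compare with fluoro and nitro.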